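The compounds below may be only part of what the source reports. "The series", "measured", "known", "first", "only" and "open" are said of these compounds alone.

Measured in a functional assay on NCI-H460 cells (Homo sapiens) for antiproliferative activity, with a stated time of 72 h; on this read-out lower numbers stand for stronger inhibition and higher numbers for weaker inhibition:
- compound 1 `CCCCC#Cc1cc([C@@H]2O[C@H](CO)[C@@H](O)[C@H]2O)n2ncnc(N)c12` gives 1700 nM
- compound 2 `Nc1ncnn2c([C@@H]3O[C@H](CO)[C@@H](O)[C@H]3O)cc(C#Cc3ccc(F)cc3)c12` gives 79400 nM
- compound 3 `Nc1ncnn2c([C@@H]3O[C@H](CO)[C@@H](O)[C@H]3O)cc(C#Cc3cccs3)c12` gives 26600 nM

Compound 2 carries the highest number of the three. Compound 4 `Nc1ncnn2c([C@@H]3O[C@H](CO)[C@@H](O)[C@H]3O)cc(C#Cc3ccccc3)c12` is still to be measured. It differs from compound 2 by hydrogen in place of fluoro on an aromatic carbon, para to a large group.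

Among the compounds with values here, no measured step makes this exact change. The nearest is a 3.0-fold lower number from compound 2 to compound 3 (0.47 log units; beyond the scatter), a modest step that swaps one aromatic group on the triple-bonded carbon for another. The large steps of a 47-fold higher number from compound 1 to compound 2 (1.67 log units; beyond the scatter) and a 16-fold higher number from compound 1 to compound 3 (1.19 log units; beyond the scatter) both start from butyl and bear less on this change, since compound 4 keeps an aromatic group there.

The change here is smaller than any of these, so no step beyond the scatter is expected in this assay. The expected step is a 1.3-fold lower number from compound 2 to compound 4 (0.12 log units; within the scatter). The estimate for compound 4 is 60000 nM, with an expected range of 25000 nM to 120000 nM.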

Compound 4, half-maximal inhibitory concentration: 38500 nM
Compound 4: the middle estimate sits 1.6-fold (0.19 log units) above what was measured, and the stated range covers the measured number.
By their numbers in this assay, from the lowest: compound 1; then compounds 3 and 4 (each within the scatter of the next); then compound 2.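

In this assay, taking the fluoro off the 4-fluorophenyl group is a step of its own (a 2.1-fold lower number from compound 2 to compound 4 (0.31 log units; beyond the scatter)), so even this single atom, para to a large group, shifts the read-out slightly beyond the scatter. Phenyl and thiophen-2-yl on the triple-bonded carbon cannot be told apart (a 1.4-fold higher number from compound 3 to compound 4 (0.16 log units; within the scatter)), while the butyl of compound 1 still gives a far lower number than phenyl (a 23-fold higher number from compound 1 to compound 4 (1.36 log units; beyond the scatter)), and this holds for all three aromatic groups shown. Nothing at hand explains these differences.

Open: whether a methoxy or an amine in place of the fluoro moves the number up or down relative to phenyl. Also open, going by these compounds, is whether a longer chain in place of butyl goes lower than compound 1.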